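A few compounds are considered here, and "the series" means these few. Any claim that something is new, unique, unknown or untested is made for them only; others in the source may bear on it.

Measured so far:
compound 1 `COC(=O)c1ccc(-c2cnc(C(=O)CCc3ccc(-c4ccccc4)cc3)o2)nc1`, 2.2 nM
compound 2 `COC(=O)c1cccc(-c2cnc(C(=O)CCc3ccc(OC4CCN(C(=O)OC(C)(C)C)CC4)cc3)o2)n1`, 32 nM

In an assay for inhibition of Fatty-acid amide hydrolase 1 (Rattus norvegicus) (on this read-out higher numbers stand for weaker inhibition and lower numbers for stronger inhibition), compound 1 gives the lowest of the two numbers; compound 2 stands at a markedly higher number, beyond the scatter. Compound 3 `CN(C)C(=O)c1cnc(C(=O)CCc2ccc(-c3ccccc3)cc2)o1` is not yet measured. It differs from compound 1 in one place: dimethylcarbamoyl in place of 5-(methoxycarbonyl)pyridin-2-yl on an aromatic carbon. For the measured compounds named here, no step between measured compounds matches this change, so the expectation rests on compound 1 alone. A weakening step of some size is expected, a 14-fold higher number from compound 1 to compound 3 (1.13 log units; beyond the scatter), since a much smaller group replaces the substituted pyridine. Compound 3 is expected at 30 nM, within 8 nM to 150 nM.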

Compound 3, inhibition constant: 3 nM
For compound 3 the middle estimate is 10-fold (1.00 log units) above the measured one; the whole stated range lies above it.
By their numbers in this assay, from the lowest: compounds 1 and 3 (each within the scatter of the next); then compound 2.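

In this assay, dimethylcarbamoyl in place of 5-(methoxycarbonyl)pyridin-2-yl on the aromatic carbon next to the ring oxygen gives a 1.4-fold higher number from compound 1 to compound 3 (0.13 log units; within the scatter). At this position, then, the pyridine ring and its methyl ester are not needed to keep the number low, since a group with no ring serves as well within the scatter. Nothing measured here accounts for this result. Still open, going by these compounds, is whether a carboxylic acid or a primary amide at this carbon would do the same. Also open, on these data alone, is whether dimethylcarbamoyl would hold its number with the side chain of compound 2.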